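Compound 4 and a cytotoxicity limit

A few compounds are considered here, and "the series" means these few. Any claim that something is new, unique, unknown or untested is made for them only; others in the source may bear on it.

In an ADME assay on MT4 cells (Homo sapiens) for cytotoxicity, read by XTT assay, with a stated time of 5 days (a higher number here means that more compound is tolerated, a lower number that less compound is tolerated), compound 3 `COC(=O)N[C@H](C(=O)NN(CC[C@@](O)(Cc1ccccc1)C(=O)N[C@H]1c2ccccc2C[C@H]1O)Cc1ccc(-c2cc(F)cc(F)c2)cc1)C(C)(C)C` gives > 10000 nM as a limit and not as a number. Compound 1 `COC(=O)N[C@H](C(=O)NN(CC[C@@](O)(Cc1ccccc1)C(=O)N[C@H]1c2ccccc2C[C@H]1O)Cc1ccc(-c2ccccc2)cc1)C(C)(C)C` gives > 10000 nM and this too is a limit. Compound 2 `COC(=O)N[C@H](C(=O)NN(CC[C@@](O)(Cc1ccccc1)C(=O)N[C@H]1c2ccccc2C[C@H]1O)Cc1ccc(-c2ccncc2)cc1)C(C)(C)C` gives > 10000 nM and this is again a limit.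

The change to compound 4 `COC(=O)N[C@H](C(=O)NN(CC[C@@](O)(Cc1ccccc1)C(=O)N[C@H]1c2ccccc2C[C@H]1O)Cc1ccc(-c2cnn(C)c2)cc1)C(C)(C)C` puts 1-methyl-1H-pyrazol-4-yl in place of 3,5-difluorophenyl on an aromatic carbon and leaves the shared core as it is. Three measured steps of the same kind bear on this change. They are a step that the two limits leave unreadable from compound 1 to compound 2 and a step that the two limits leave unreadable from compound 1 to compound 3 and a step that the two limits leave unreadable from compound 2 to compound 3 and none of them offers a size to carry over. Compound 1, compound 2 and compound 3 all stay at the limit of > 10000 nM in this assay, at which 3 of the 3 values shown sit, and so no step beyond the scatter is expected in this assay in either direction. The estimated step is a step that the limit leaves unreadable from compound 3 to compound 4 and it should be read with that limit in mind. For compound 4 the estimated value is 20000 nM with an expected range from 8000 nM to 50000 nM and the result will most likely be reported as a limit again.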

Compound 4, half-maximal cytotoxic concentration: > 10000 nM
Compound 4 gave a limit, no number; the forecaster's own chance of this, stated with the estimate: 85%; the middle value is on the limit's open side.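

In this assay compound 4 gives > 10000 nM, which is a limit and not a number. For the compounds shown here, no step among compound 1, compound 2, compound 3 and compound 4 can be read: the limit of > 10000 nM in this assay, at which 4 of the 4 values shown sit. The compounds shown leave open whether the group on the aromatic carbon affects cytotoxicity at all.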